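Acetoxy Added Beside the Ring of a Hydroxyalkyl Quinone

The source may report more compounds than this note shows. Statements on the series, on what has been measured and on what is new or still open speak of the compounds shown alone.

Measured compounds:
Compound 1: `COC1=CC(=O)C(OC)=C(CCCCCCCCO)C1=O` — 1840 nM
Compound 2: `COC1=CC(=O)C(OC)=C(CCCCCCCCCCO)C1=O` — 1750 nM

Two compounds share one core and differ only in the chain that ends in a hydroxy group. In an assay for inhibition of Polyunsaturated fatty acid 5-lipoxygenase (Homo sapiens), read by HPLC, with stated times of 15 min and 10 min (on this read-out higher numbers stand for weaker inhibition and lower numbers for stronger inhibition), compound 1 gives 1840 nM, and compound 2 gives 1750 nM. The step of a 1.1-fold lower number from compound 1 to compound 2 (0.02 log units; within the scatter) therefore shows no change beyond the scatter, and compound 2 stands with the lowest of the two numbers, its nearest neighbour being compound 1 within the scatter.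

Compound 3 is `COC1=CC(=O)C(OC)=C(C(CCCCCCCCCO)OC(C)=O)C1=O`. It differs from compound 2 by acetoxy in place of hydrogen on a saturated chain carbon bound to a double-bonded ring carbon and a saturated chain carbon. For the measured compounds named here, no measured step touches this kind of change: the only step available, a 1.1-fold lower number from compound 1 to compound 2 (0.02 log units; within the scatter), concerns chain length alone and was within the scatter, so it says nothing about adding a group on the chain carbon bound to the ring. The expectation for compound 3 in this assay must therefore rest on the unchanged core and chain, with a wide range around the value of compound 2. The estimated step of a 1.1-fold higher number from compound 2 to compound 3 (0.06 log units; within the scatter) is expected to be none beyond the scatter.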

Compound 3, half-maximal inhibitory concentration: 490 nM
Compound 3: middle estimate off by 4.1-fold (0.61 log units), on the high side, outside the stated range (below it).
By their numbers in this assay, from the lowest: compound 3; then compounds 2 and 1 (each within the scatter of the next).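

In this assay, the saturated chain carbon bound to a double-bonded ring carbon and a saturated chain carbon proves to be a place where a change registers: acetoxy in place of hydrogen there gives a 3.6-fold lower number from compound 2 to compound 3 (0.55 log units; beyond the scatter), while the chain-length step, a 1.1-fold lower number from compound 1 to compound 2 (0.02 log units; within the scatter), did not move the read-out beyond the scatter. For the compounds shown here, this modest change is thus the first step to lie beyond the scatter, and it comes from a substitution on the chain rather than from the length of the chain. Nothing at hand bears on why the number falls, so the result stands as an observation only. The compounds shown leave open whether acetoxy in particular matters or whether another group on this same carbon, such as hydroxy, methoxy or an amine, would give a similar step. They also leave open whether the step would hold on the chain of compound 1, or with a carboxylic acid in place of the hydroxy group that ends the chain.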